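The compounds below may be only part of what the source reports. "The series", "measured", "known", "first", "only" and "open" are said of these compounds alone.

Compound 1 `O=c1ccoc2cc(OCc3cn(Cc4cccc(F)c4)nn3)ccc12`: in a functional assay on MDA-MB-231 cells (Homo sapiens) for cytotoxicity, read by MTT assay, with a stated time of 48 h (a higher number here means a weaker inhibitor, a lower number a stronger inhibitor), compound 1 gives > 100000 nM, which is a limit of the assay and not a number.
Compound 2 `CC(C)(C)c1ccc(Cn2cc(COc3ccc4c(=O)ccoc4c3)nn2)cc1`: in this assay compound 2 gives > 100000 nM, again a limit.
Compound 3 `C#CCOc1ccc2c(=O)ccoc2c1`: in this assay compound 3 gives > 100000 nM, also a limit.

Compound 2 thus stands at the limit of > 100000 nM in this assay, at which 3 of the 3 values shown sit; none of the three measured compounds yields a number. Compound 4 `COc1ccc(Cn2cc(COc3ccc4c(=O)ccoc4c3)nn2)cc1` differs from compound 2 by methoxy in place of tert-butyl on an aromatic carbon. For the measured compounds named here, no step between measured compounds is available here, so the size of this change cannot be read from earlier pairs. Since every value shown sits at the limit, no shift beyond the scatter in either direction is expected in this assay. Compound 4 is therefore estimated at 150000 nM, with a range from 30000 nM to 1000000 nM, most likely reported once more only as a limit. The expected step that the limit leaves unreadable from compound 2 to compound 4 is essentially none.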

Compound 4, half-maximal inhibitory concentration: > 100000 nM
Compound 4: a limit, no number; the forecaster's own chance of this, stated with the estimate: 80%; the middle value is on the limit's open side.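

No step can be read from compound 2 to compound 4 or from compound 1 to compound 4, since each result is a limit of the assay and not a number: the limit of > 100000 nM in this assay, at which 4 of the 4 values shown sit.

The compounds shown leave open how strong each one really is, and whether exchanging these groups changes that strength at all.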